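The compounds below may be only part of what the source reports. "The series", "measured", "known", "first", "only" and "open" are said of these compounds alone.

Series notes. Three compounds have been run in an assay on V79 cells for inhibition of cytochrome P450 11B2, mitochondrial (Homo sapiens), read by HTRF, with a stated time of 1 h; on this read-out higher numbers stand for weaker inhibition and lower numbers for stronger inhibition. Compound 1 `Fc1cc2nc(-c3cccnc3)n(C3CC3)c2cc1F` gives 2.1 nM. Compound 2 `c1cncc(-c2nc3ccccc3n2C2CC2)c1` gives 49 nM. Compound 3 `COc1ccc2nc(-c3cccnc3)n(C3CC3)c2c1` gives 24 nM. Compound 1 stands lowest of the three, and its gaps to compound 3 and to compound 2 are both beyond the scatter; the difference between the core of compound 1 and the core of compound 2 is not broken down here.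

One single-point change is measured within the set: methoxy in place of hydrogen on an aromatic carbon This change gave a 2.0-fold lower number from compound 2 to compound 3 (0.31 log units; beyond the scatter).

Compound 4 `COc1cncc(-c2nc3cc(F)c(F)cc3n2C2CC2)c1` is not yet measured in this assay. It derives from compound 1 by the same kind of change, not the same: methoxy in place of hydrogen on an aromatic carbon The surroundings differ. In compound 3 the methoxy sits on a six-membered aromatic ring of carbon only, part of a fused or bridged system of two rings, meta to a fused ring and para to a fused ring; in compound 4 it sits on a six-membered aromatic ring with 1 nitrogen, two atoms from the ring nitrogen, meta to a large group.

For compound 4 the step expected in this assay is a 1.4-fold lower number from compound 1 to compound 4 (0.15 log units; within the scatter). Among the measured compounds shown here, this expectation rests on compound 3, whose step was a 2.0-fold lower number from compound 2 to compound 3 (0.31 log units; beyond the scatter), set beside compound 1 at 2.1 nM, with only that one precedent and a different place to lean on. Compound 4 is therefore estimated at 1.5 nM, with a likely range from 0.5 nM to 5 nM.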

Compound 4, half-maximal inhibitory concentration: 0.4 nM
The estimate for compound 4 lay 3.8-fold (0.57 log units) above the measured number; measured number outside the range, below it.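

In this assay, methoxy in place of hydrogen on an aromatic carbon gives a 5.3-fold lower number from compound 1 to compound 4 (0.72 log units; beyond the scatter), a step beyond the scatter on the core of compound 1. Set beside the earlier step, the change points the same way on both cores, and the two steps cannot be told apart in size: the same change on two cores in this assay, a 2.0-fold lower number (0.31 log units; beyond the scatter) from compound 2 to compound 3 and a 5.3-fold lower number (0.72 log units; beyond the scatter) from compound 1 to compound 4, 2.6-fold (0.41 log units) apart, within the scatter of two such steps. Among the compounds shown here, this does not show a transferable effect of methoxy across the series, since the evidence is only two pairs and the group stands in a different setting in each, on a six-membered aromatic ring of carbon only in compound 3 and on a six-membered aromatic ring with 1 nitrogen, two atoms from the ring nitrogen, in compound 4, so the influence of the core cannot be separated from that of the place.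

The compounds shown leave open whether methoxy at the place it holds in compound 4 would give a comparable step on the core of compound 2, which would separate the contribution of the place from that of the core. They also leave open how far that place tolerates other groups, such as ethoxy, an amine or a nitrile, in place of methoxy.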